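This account rests on a few compounds, and the source may have more. Where it says the series, first, only, none or still open, it means among the compounds named here.

Measured in an in vitro assay on Sf9 cells for inhibition of cytochrome P450 2J2 (Homo sapiens); a lower number here means a stronger inhibitor, a higher number a weaker inhibitor:

- compound 1 `CCc1ccc(C(=O)CCCN2CCC(C(O)(c3ccccc3)c3ccccc3)CC2)cc1`: 600 nM
- compound 2 `O=C(CCCN1CCC(C(O)(c2ccccc2)c2ccccc2)CC1)c1ccc(CCO)cc1`: 1300 nM
- compound 3 `O=C(CCCN1CCC(C(O)(c2ccccc2)c2ccccc2)CC1)c1ccc(CC(F)F)cc1`: 2200 nM

Compound 3 stands highest of these three numbers. Its gap to compound 2, a 1.7-fold higher number from compound 2 to compound 3 (0.23 log units; within the scatter), is within the scatter, while its gap to compound 1, a 3.7-fold higher number from compound 1 to compound 3 (0.56 log units; beyond the scatter), is beyond it. The next compound, compound 4 `O=C(CCCN1CCC(C(O)(c2ccccc2)c2ccccc2)CC1)c1ccc(Br)cc1`, differs from compound 3 by a single change: bromo in place of 2,2-difluoroethyl on an aromatic carbon.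

For the measured compounds named here, two measured steps touch the same spot on the shared core. Both a 3.7-fold higher number from compound 1 to compound 3 (0.56 log units; beyond the scatter) and a 1.7-fold higher number from compound 2 to compound 3 (0.23 log units; within the scatter) swap one group for another on the saturated chain carbon bound to the aromatic carbon, and both are modest. Going by the values given here, no measured step removes the chain and puts a single atom on the ring itself, so the direction rests on weaker ground. Because compound 1, with the smallest chain group, gives 600 nM, the expectation for compound 4 is a modest step toward lower numbers, a 2.4-fold lower number from compound 3 to compound 4 (0.39 log units; beyond the scatter). Compound 4 is therefore estimated at 900 nM in this assay, with a range from 350 nM to 2500 nM.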

Compound 4, half-maximal inhibitory concentration: 4200 nM
Beside the measured number, compound 4's estimate is 4.7-fold (0.67 log units) below it, outside the stated range (above it).
By their numbers in this assay, from the lowest: compound 1; then compounds 2, 3 and 4 (each within the scatter of the next, the first and the last beyond it).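

In this assay, this is the first change shown that replaces the whole chain on the aromatic ring with a single atom, and a 1.9-fold higher number from compound 3 to compound 4 (0.28 log units; within the scatter) leaves bromo and 2,2-difluoroethyl within the scatter of each other at this position. Against the other two groups the bromo does separate, with a 3.2-fold higher number from compound 2 to compound 4 (0.51 log units; beyond the scatter) for 2-hydroxyethyl and a 7.0-fold higher number from compound 1 to compound 4 (0.85 log units; beyond the scatter) for ethyl, so the group with the fewest heavy atoms does not give the lowest number, and ethyl keeps that place. Nothing measured here accounts for these differences.

What the compounds shown leave open is whether ethyl is a special case or the start of a trend, which a propyl or butyl chain at this position would test. An amine or a carboxylic acid in the same place would show how far the number moves with groups of quite another kind.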